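The source may report more compounds than this note shows. Statements on the series, on what has been measured and on what is new or still open speak of the compounds shown alone.

Measured compounds:
compound 1 `CCCC(=O)c1ccc(OCCCCOc2ccc(F)c(C(=O)O)c2)c(C)c1O` gives 74 nM in an assay on HEK293 cells for positive allosteric modulation of metabotropic glutamate receptor 2 (Rattus norvegicus), read by thallium flux, with a stated time of 2.5 min; on this read-out lower numbers stand for an effect already at smaller amounts and higher numbers for an effect only at larger amounts of compound;
compound 2 `Cc1c(OCCCCOc2cccc(C(=O)O)c2)ccc(C(=O)CC(C)C)c1O` gives 222 nM;
compound 3 `Cc1cc(OCCCCOc2ccc(C(=O)CC(C)C)c(O)c2C)ccc1C(=O)O` gives 173 nM.

Compound 3 stands second highest of the three numbers. Its nearest neighbour is compound 2, within the scatter, while compound 1 sits beyond the scatter at a lower number.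

Compound 4 `Cc1c(OCCCCOc2ccc(F)c(C(=O)O)c2)ccc(C(=O)CC(C)C)c1O` differs from compound 3 in one place: 3-carboxy-4-fluorophenyl in place of 4-carboxy-3-methylphenyl on an oxygen on a saturated carbon. Within the data shown here, the only measured step on the same oxygen, a 1.3-fold lower number from compound 2 to compound 3 (0.11 log units; within the scatter), was within the scatter, and compound 1, which carries the same 3-carboxy-4-fluorophenyl with a different acyl chain, gives the lowest value in this assay. The step of a 1.4-fold lower number from compound 3 to compound 4 (0.16 log units; within the scatter) is therefore expected to be modest and toward a lower number. Compound 4 is estimated at 120 nM, within 50 nM to 300 nM.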

Compound 4, half-maximal effective concentration: 153 nM
Compound 4: middle estimate off by 1.3-fold (0.11 log units), on the low side; the measured number falls inside the stated range.
By their numbers in this assay, from the lowest: compound 1; then compounds 4, 3 and 2 (each within the scatter of the next).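

In this assay, the exchange of aryl groups on the oxygen stays within the scatter (a 1.1-fold lower number from compound 3 to compound 4 (0.05 log units; within the scatter)), and so does fluoro in place of hydrogen on an aromatic carbon (a 1.5-fold lower number from compound 2 to compound 4 (0.16 log units; within the scatter)). Among these compounds, the one step beyond the scatter lies in the acyl chain, with methyl in place of hydrogen on a saturated chain carbon (a 2.1-fold higher number from compound 1 to compound 4 (0.32 log units; beyond the scatter)), so 3-carboxy-4-fluorophenyl alone does not bring the number to that of compound 1. On these data alone, what stays open is how chloro in place of fluoro, or a tetrazole in place of the carboxylic acid, would read in this assay. No measurement shown here accounts for these steps.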